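This account rests on a few compounds, and the source may have more. Where it says the series, first, only, none or still open, it means among the compounds named here.

Measured so far:
compound 1 `N#Cc1ccc(Nc2nccc(SC3CCCCC3)n2)cc1`: > 402000 nM
compound 2 `N#Cc1ccc(Nc2nccc(OC3CCCCC3)n2)cc1`: 322000 nM

In an ADME assay on MT4 cells (Homo sapiens) for cytotoxicity, read by MTT assay (a higher number here means that more compound is tolerated, a lower number that less compound is tolerated), compound 1 reaches only a limit, > 402000 nM. Compound 2 gives 322000 nM in this assay. Compound 1 sits at the limit of > 402000 nM in this assay, at which 1 of the 2 values shown sits, so compound 2 gives the only number shown. The step of an at least 1.2-fold lower number from compound 1 to compound 2 (0.09 log units; that floor lies within the scatter) thus has only a floor, and that floor lies within the usual scatter. Compound 3 `N#Cc1ccc(Nc2nccc(OC3CCCC3)n2)cc1` differs from compound 2 by cyclopentyl in place of cyclohexyl on an oxygen on an aromatic ring. Within the data shown here, no measured step alters the ring carried on the oxygen; the one measured step, an at least 1.2-fold lower number from compound 1 to compound 2 (0.09 log units; that floor lies within the scatter), swaps the atom that links the ring to the core instead, so it gives no guide to the size of this change. With nothing pointing either way, the expectation for compound 3 in this assay is a step of a 1.1-fold lower number from compound 2 to compound 3 (0.03 log units; within the scatter), that is, none beyond the scatter. Compound 3 is expected at 300000 nM, within 150000 nM to 600000 nM.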

Compound 3, half-maximal cytotoxic concentration: >= 339000 nM
Compound 3: only a limit was reported; the forecaster's own chance of this, stated with the estimate: 40%; middle value at least 1.1-fold (0.05 log units) away from the limit.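

In this assay, among these compounds, the change from cyclohexyl to cyclopentyl on an oxygen on an aromatic ring gives an at least 1.0-fold higher number from compound 2 to compound 3 (0.02 log units; that floor lies within the scatter) and so shows no loss of tolerance beyond the scatter, which is the first reading of a change to the ring itself rather than to the atom linking it to the core. Compound 3 gives >= 339000 nM as a limit and not as a number. Compound 1 and compound 3 both carry limits, so the step between them cannot be read.

As far as these compounds go, how far the value of compound 3 lies past its limit stays open. Also open, from the compounds shown here alone, is how tolerance would respond if the oxygen carried a much smaller ring such as cyclopropyl, a longer open chain such as n-hexyl, or a ring bearing an amine or a carboxylic acid.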